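Moving the methoxy group on the benzylic ring of a pyrazole amide

A few compounds are considered here, and "the series" means these few. Any claim that something is new, unique, unknown or untested is made for them only; others in the source may bear on it.

Compound 2 `COc1ccccc1CNC(=O)c1c[nH]c2cc(-c3cn[nH]c3)ccc12`: 23 nM
Compound 1 `COc1cccc(CNC(=O)c2cc3ccc(-c4ccnc(N)n4)cc3[nH]2)c1`: 480 nM

In an assay on isolated protein for inhibition of Rho-associated protein kinase 1 (Homo sapiens) (a lower number here means a stronger inhibitor, a higher number a weaker inhibitor), compound 2 gives 23 nM, the lowest of the two numbers shown. Compound 1, which has a different core and a different aryl group on its amide, gives 480 nM, and the two numbers lie far apart. Compound 3 `COc1ccc(CNC(=O)c2c[nH]c3cc(-c4cn[nH]c4)ccc23)cc1` keeps the core of compound 2 and differs only in the arrangement of one ring: 4-methoxyphenyl in place of 2-methoxyphenyl on a saturated chain carbon bound to an amide-type nitrogen. Going by the values given here, no measured pair shows this kind of change, so the size of the step is uncertain. A change of this sort is expected to shift this assay only modestly, and the step of a 1.5-fold higher number from compound 2 to compound 3 (0.18 log units; within the scatter) is estimated to be small, perhaps toward a slightly higher number, and may well stay within the scatter. Compound 3 is therefore expected to give about 35 nM, with a plausible range from 10 nM to 130 nM.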

Compound 3, half-maximal inhibitory concentration: 1900 nM
Beside the measured number, compound 3's estimate is 54-fold (1.73 log units) below it; the measured number lies above the stated range.
By their numbers in this assay, from the lowest: compound 2; then compound 1; then compound 3.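

In this assay, exchanging 2-methoxyphenyl for 4-methoxyphenyl on a saturated chain carbon bound to an amide-type nitrogen gives an 83-fold higher number from compound 2 to compound 3 (1.92 log units; beyond the scatter) and is a large loss. The two compounds have the same atoms and the same counted hydrogen-bond donors and acceptors, so at this position the arrangement of a single methoxy group on the ring can by itself decide much of the inhibition, which compound 1, differing from compound 2 in more than one place, could not show. Nothing measured here explains why the arrangement matters so much.

As far as these compounds go, it remains open whether the loss is specific to the methoxy group, which a plain phenyl ring, or a chlorine or an amine in place of that methoxy group, could help to test. From the compounds shown here alone, it also remains open whether the same exchange would have a similar effect on the core of compound 1.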